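Swapping methyl for chloro in a series that shows no activity

A few compounds are considered here, and "the series" means these few. Any claim that something is new, unique, unknown or untested is made for them only; others in the source may bear on it.

Compound 3 `Cc1cc(Cl)ccc1C(=O)Nc1ccc(Cl)c(-c2nnc3c(Cl)cccn23)c1` is an amide in which one ring carries a methyl and a chloro group. In a functional assay on HeLa cells (Homo sapiens) for antiproliferative activity, read by MTT assay, with a stated time of 72 h (on this read-out higher numbers stand for weaker inhibition and lower numbers for stronger inhibition), compound 3 gives > 100000 nM, which is a limit of the assay and not a measured number. Two relatives stand at the same place. Compound 2 `O=C(Nc1ccc(Cl)c(-c2nnc3c(Cl)cccn23)c1)c1ccc(Cl)cc1` has a hydrogen where compound 3 has the methyl, and in this assay compound 2 gives > 100000 nM, again a limit. Compound 1 `CS(=O)(=O)c1ccc(C(=O)Nc2ccc(Cl)c(-c3nnc4c(Cl)cccn34)c2)c(Cl)c1` is a further relative of the same core, and in this assay compound 1 gives > 100000 nM, also a limit. Among the compounds with values here, the one change that links two measured compounds, a step that the two limits leave unreadable from compound 2 to compound 3, cannot be sized, because the limit of > 100000 nM in this assay, at which 3 of the 3 values shown sit, is where both of its ends sit.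

Compound 4 `O=C(Nc1ccc(Cl)c(-c2nnc3c(Cl)cccn23)c1)c1ccc(Cl)cc1Cl` differs from compound 3 by chloro in place of methyl on an aromatic carbon. Within the data shown here, no measured step speaks to this change, since every value shown is a limit, so there is nothing that points toward a gain or a loss in this assay beyond the scatter. The expectation is therefore that compound 4 also reaches only the limit, with an estimated value of 100000 nM in a range from 30000 nM to 300000 nM. The expected step of a number no higher from compound 3 to compound 4 (the limit leaves the size open) is essentially none.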

Compound 4, half-maximal inhibitory concentration: > 100000 nM
Compound 4: no number, only a limit; the forecaster's own chance of this, stated with the estimate: 85%; the middle value sits exactly at the limit.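

Compound 4 adds no readable step to compound 1, compound 2 or compound 3, because all four values are limits and not numbers: the limit of > 100000 nM in this assay, at which 4 of the 4 values shown sit.

The compounds shown leave open which change to these structures, if any, would give a measured number, and so how methyl, chloro, hydrogen and methylsulfonyl compare.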